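Losing the Phenyl from the Benzoyl of Compound 3

A few compounds are considered here, and "the series" means these few. Any claim that something is new, unique, unknown or untested is made for them only; others in the source may bear on it.

In a functional assay on K562 cells (Homo sapiens) for antiproliferative activity, read by MTT assay (on this read-out higher numbers stand for weaker inhibition and lower numbers for stronger inhibition), compound 1 `O=C1NC(c2ccccc2)CN1S(=O)(=O)c1ccc2c(c1)CCCN2` gives > 20000 nM which is a limit of the assay and not a number. In this assay compound 2 `COC(=O)N1CCCc2cc(S(=O)(=O)N3CC(c4ccccc4)NC3=O)ccc21` gives > 20000 nM which is likewise a limit. Among the measured compounds shown here, compound 3 `O=C(c1ccccc1)N1CCCc2cc(S(=O)(=O)N3CC(c4ccccc4)NC3=O)ccc21` gives 1220 nM and is the only compound of the three with a true number, so it stands alone as the reference point.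

Compound 4 `O=C1NC(c2ccccc2)CN1S(=O)(=O)c1ccc2c(c1)CCCN2C(=O)C(F)(F)F` has not yet been measured. It carries trifluoromethyl in place of phenyl on a carbonyl carbon and keeps the rest of compound 3 unchanged.

For the measured compounds named here, two measured steps bear on this change. Benzoyl in place of hydrogen gave an at least 16-fold lower number from compound 1 to compound 3 (1.21 log units; beyond the scatter) and shows that this nitrogen substituent matters. The closer guide is an at least 16-fold lower number from compound 2 to compound 3 (1.21 log units; beyond the scatter) with phenyl in place of methoxy on a carbonyl carbon. Trifluoromethyl is not methoxy, but the phenyl leaves in both cases, so weaker inhibition is expected from reading that step backwards, probably by less than its full size. The expected change is a 5.7-fold higher number from compound 3 to compound 4 (0.76 log units; beyond the scatter) in this assay and it points toward a higher number. For compound 4 the estimated value is 7000 nM with an expected range from 1800 nM to 20000 nM in this assay.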

Compound 4, half-maximal inhibitory concentration: > 20000 nM
Compound 4 was reported as a limit; the forecaster's own chance of this, stated with the estimate: 35%; middle value at least 2.8-fold (0.45 log units) away from the limit.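

In this assay, trifluoromethyl in place of phenyl on the carbonyl carbon gives an at least 16-fold higher number from compound 3 to compound 4 (1.21 log units; beyond the scatter), so a carbonyl on this nitrogen is not enough on its own to give the activity seen for compound 3. Compound 2 had already shown this outcome with methoxy on the same carbonyl carbon, and compound 4 now shows it with trifluoromethyl, so neither of the two replacements shown for phenyl keeps a measurable number. The value of compound 4 is a limit of the assay and not a number, which makes the size of this step a minimum only, and the steps from compound 1 and compound 2 to compound 4 cannot be read because both ends of each are limits: the limit of > 20000 nM in this assay, at which 3 of the 4 values shown sit.

The compounds shown leave open whether the phenyl itself is required or whether another carbon group on this carbonyl carbon, such as cyclohexyl or benzyl, would also give a measurable number. They also leave open how a substituent on the phenyl, such as a methoxy group or a chlorine atom, would shift the number of compound 3 in this assay.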